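Benzyl substitution: methoxy to fluoro

The source may hold more compounds than are shown below. What is called first, only, known or untested is meant among the compounds shown, and "the series" means these compounds.

In a functional assay on HCT-116 cells (Homo sapiens) for inhibition, read by MTT assay, with a stated time of 48 h (on this read-out higher numbers stand for weaker inhibition and lower numbers for stronger inhibition), compound 1 `COc1cc(-c2nnc(SCc3ccccc3)n2-c2ccc(N(C)C)cc2)cc(OC)c1OC` reads 54000 nM as the higher number. Within the data shown here, compound 2 `COc1ccc(CSc2nnc(-c3cc(OC)c(OC)c(OC)c3)n2-c2ccc(N(C)C)cc2)cc1` reads 1150 nM as the lowest of the two numbers so far. The change fluoro in place of methoxy on an aromatic carbon puts fluoro in place of methoxy on an aromatic carbon para to a large group and gives compound 3 `COc1cc(-c2nnc(SCc3ccc(F)cc3)n2-c2ccc(N(C)C)cc2)cc(OC)c1OC` as the next entry. Among the measured compounds shown here, the only measured step bearing on this is a 47-fold lower number from compound 1 to compound 2 (1.67 log units; beyond the scatter) with methoxy in place of hydrogen on an aromatic carbon. For the measured compounds named here, no fluoro compound has been measured, so a partial return toward the higher number is expected in this assay and the estimated step is a 7.0-fold higher number from compound 2 to compound 3 (0.84 log units; beyond the scatter) for now. Compound 3 is expected at 8000 nM within 2000 nM to 32000 nM as the estimated range.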

Compound 3, half-maximal inhibitory concentration: > 60000 nM
Compound 3 was reported as a limit (the forecaster's own chance of this, stated with the estimate: 5%); middle value at least 7.5-fold (0.87 log units) away from the limit.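

In this assay compound 3 gives > 60000 nM as a limit of the assay, not a number. The change from 4-methoxybenzyl to 4-fluorobenzyl gives an at least 52-fold higher number from compound 2 to compound 3 (1.71 log units; beyond the scatter) and so the gain at this position is not kept with fluoro. Fluoro in place of hydrogen gives an at least 1.1-fold higher number from compound 1 to compound 3 (0.04 log units; that floor lies within the scatter) and so shows none of the gain seen with methoxy.

From the compounds shown here alone, how far compound 3 lies past its limit stays open. Also open, going by these compounds, is whether the gain is specific to methoxy or extends to ethoxy, hydroxyl or dimethylamino at this position.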